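Swapping a Triazole for a Pyrrolidinone on an Aryl Sulfonamide

This account rests on a few compounds, and the source may have more. Where it says the series, first, only, none or still open, it means among the compounds named here.

Compound 1 `O=S(=O)(c1ccc(-n2cncn2)cc1)N1CCCc2ccccc21` was tested in a functional assay on MCF7 cells (Homo sapiens) for antiproliferative activity, read by fluorescence and SYBR Green assay, with a stated time of 24 h; a higher number here means a weaker inhibitor, a lower number a stronger inhibitor. In this assay, among the compounds with values here, compound 1 reaches only the limit, > 5000 nM, so its potency is not given as a number; it is the one value sitting at the limit of > 5000 nM in this assay, at which 1 of the 2 values shown sits. Compound 2 `CN1CCN(S(=O)(=O)c2ccc(N3CCC=N3)cc2)c2ccccc21`, built on a different core, gives 7 nM in this assay. Compound 3 `O=C1CCCN1c1ccc(S(=O)(=O)N2CCCc3ccccc32)cc1` keeps the core of compound 1 and carries the change (2-oxopyrrolidin-1-yl in place of 1H-1,2,4-triazol-1-yl on an aromatic carbon). Within the data shown here, no pair of measured compounds shows how this exchange alone moves the read-out, and the two measured values share neither core nor side group, so no direct comparison is drawn. Compound 3 is expected to gain by about an at least 2.5-fold lower number from compound 1 to compound 3 (0.39 log units; beyond the scatter) in this assay, a step beyond the usual scatter but uncertain. Compound 3 is thus estimated at 2000 nM, within a range of 200 nM to 10000 nM.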

Compound 3, half-maximal inhibitory concentration: 17 nM
Estimate against measurement, compound 3: 120-fold (2.07 log units) above; the whole stated range lies above it.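

On the core of compound 1, the group on the aromatic carbon para to a large group strongly governs the read-out in this assay: replacing 1H-1,2,4-triazol-1-yl with 2-oxopyrrolidin-1-yl gives an at least 290-fold lower number from compound 1 to compound 3 (2.46 log units; beyond the scatter). Within the data shown here, with this one change, compound 3 reaches 17 nM, showing that this core, which the earlier compounds left without a numerical value, can give a low number. The value of compound 1, > 5000 nM, is a limit of the assay and not a number: the limit of > 5000 nM in this assay, at which 1 of the 3 values shown sits.

The exchange alters the ring and adds a carbonyl together, so the compounds shown do not separate what each contributes. They also leave open how a plain pyrrolidin-1-yl, a morpholine or an open-chain acetamide would read at this position.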